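Working notes: from compound 3 to compound 4

The source may hold more compounds than are shown below. What is called first, only, known or untested is meant among the compounds shown, and "the series" means these compounds.

Compound 1 `CN(C)c1ncnc2c1ncn2COCCO`: > 350 ug/mL, a limit of the assay.
Compound 2 `Nc1nc2c(nc(Br)n2COCCO)c(=O)[nH]1`: 225 ug/mL.
Compound 3 `Nc1nc2c(nc(I)n2COCCO)c(=O)[nH]1`: >= 250 ug/mL, a limit of the assay.
Compound 4 `Nc1nc2c(nc(N)n2COCCO)c(=O)[nH]1`: not yet measured.

In a functional assay (Oryctolagus cuniculus) for inhibition (on this read-out higher numbers stand for weaker inhibition and lower numbers for stronger inhibition), compound 1 gives > 350 ug/mL, which is a limit and not a number. Compound 2 gives 225 ug/mL. Compound 3 gives >= 250 ug/mL, again a limit. The only measured step, an at least 1.1-fold higher number from compound 2 to compound 3 (0.04 log units; that floor lies within the scatter), is itself floored at a limit (the limit of >= 250 ug/mL in this assay, at which 1 of the 3 values shown sits), so compound 3 stands at the weak end of the shown numbers, with only a limit to its name, as does compound 1 (the limit of > 350 ug/mL in this assay, at which 1 of the 3 values shown sits).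

The change to compound 4 is amino in place of iodo on an aromatic carbon. No measured step exchanges a halogen for amino; the single step shown swaps one halogen for another and stays within the scatter. Nothing in these three values therefore points to a move in either direction in this assay. The step that the limit leaves unreadable from compound 3 to compound 4 is expected to stay within the scatter. Compound 4 is expected to give about 300 ug/mL, within 150 ug/mL to 600 ug/mL.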

Compound 4, concentration for 50% inhibition: 200 ug/mL
Compound 4: middle estimate off by 1.5-fold (0.18 log units), on the high side; the range from low to high includes it.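

At this position, an aromatic carbon between two ring nitrogen atoms, the series now has its first exchange of a halogen for amino that can be read between two numbers in this assay: a 1.1-fold lower number from compound 2 to compound 4 (0.05 log units; within the scatter). Amino in place of bromo therefore leaves compound 4 and compound 2 indistinguishable on this read-out. The step from the iodo compound, an at least 1.2-fold lower number from compound 3 to compound 4 (0.09 log units; that floor lies within the scatter), rests on a limit of the assay and gives only a floor: the limit of >= 250 ug/mL in this assay, at which 1 of the 4 values shown sits.

Going by these compounds, whether any group at this position can move the number beyond the scatter stays open, and a carboxylic acid or a longer alkyl chain there would test this. On these data alone, how far the (2-hydroxyethoxy)methyl group shapes these values also stays open, as all four compounds carry it.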